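The source may report more compounds than this note shows. Statements on the series, on what has been measured and on what is new or still open speak of the compounds shown alone.

Measured so far:
Compound 1 `CCn1c(-c2ccccc2)nc2c(NC3CCC3)ncnc21` gives 6 nM in an assay on CHO cells for displacement of a labelled ligand from adenosine receptor A1 (Homo sapiens), read by scintillation counting, with a stated time of 3 h; a higher number here means a weaker inhibitor, a lower number a stronger inhibitor
Compound 2 `CCn1c(-c2ccccc2)nc2c(NC3CCCCC3)ncnc21` gives 10 nM in this assay
Compound 3 `CCn1c(-c2ccccc2)nc2c(NC3CCCC3)ncnc21` gives 3.9 nM in this assay

Compound 3 shows the lowest of the three numbers in this assay. Its gap to compound 1 is small, a 1.5-fold lower number from compound 1 to compound 3 (0.19 log units; within the scatter), so those two cannot be told apart; only against compound 2 is the gap clear, a 2.6-fold lower number from compound 2 to compound 3 (0.41 log units; beyond the scatter). Compound 4 `CCCn1c(-c2ccccc2)nc2c(NC3CCCC3)ncnc21` differs from compound 3 in one place: methyl in place of hydrogen on a saturated chain carbon, two bonds along the chain from an aromatic nitrogen. Among the measured compounds shown here, all three measured steps, a 1.7-fold higher number from compound 1 to compound 2 (0.22 log units; within the scatter), a 1.5-fold lower number from compound 1 to compound 3 (0.19 log units; within the scatter) and a 2.6-fold lower number from compound 2 to compound 3 (0.41 log units; beyond the scatter), swap the saturated ring on the nitrogen of the shared core and leave the ethyl chain untouched, so none of them directly bears on this change; they show only that the shared core tolerates small changes in size at one end. With nothing directly informing the chain extension, the expected step from compound 3 to compound 4 is a 1.0-fold higher number from compound 3 to compound 4 (0.01 log units; within the scatter), that is, none beyond the scatter. Compound 4 is therefore estimated at 4 nM in this assay, within a range of 1.5 nM to 12 nM.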

Compound 4, inhibition constant: 10 nM
Compound 4: the middle estimate sits 2.5-fold (0.40 log units) below what was measured; measured number inside the range.
By their numbers in this assay, from the lowest: compounds 3, 1, 2 and 4 (each within the scatter of the next, the first and the last beyond it).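

Lengthening the ethyl chain to propyl does register in this assay, with a step of a 2.6-fold higher number from compound 3 to compound 4 (0.41 log units; beyond the scatter) that is modest but clear. Among the compounds shown here, the earlier steps changed only the saturated ring on the nitrogen of the shared core, so this is the first reading at the chain on the aromatic nitrogen, and it shows that a single added methyl there can raise the number beyond the scatter. No measurement among those shown accounts for this step.

Going by these compounds, it remains open whether a shorter methyl, a longer butyl chain or a branched isopropyl group would continue this trend or break it. Also open, on these data alone, are a chain ending in an amine or a hydroxyl group, and whether the same extension would give a similar step with the cyclobutyl or cyclohexyl ring in place.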